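The source may hold more compounds than are shown below. What is called first, only, known or untested is meant among the compounds shown, and "the series" means these compounds.

Compound 3 `Cc1cccc(NC(=O)CCCc2[nH]c3ccccc3c2C2=C(Br)C(=O)NC2=O)c1` is one of three measured members of a shared core. In a physicochemical assay for lipophilicity (a lower number here means a more polar compound, a higher number a more lipophilic compound), compound 3 gives 2.56, and it stands level with its two neighbours: compound 1 `O=C(CCCc1[nH]c2ccccc2c1C1=C(Br)C(=O)NC1=O)Nc1ccccc1` gives 2.56 in this assay, and compound 2 `O=C(CCCCc1[nH]c2ccccc2c1C1=C(Br)C(=O)NC1=O)Nc1ccccc1` gives 2.56. The steps among them are all flat: no change at the digits printed from compound 1 to compound 3 (within the scatter), no change at the digits printed from compound 1 to compound 2 (within the scatter) and no change at the digits printed from compound 2 to compound 3 (within the scatter).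

Compound 4 `Cc1ccccc1NC(=O)CCCc1[nH]c2ccccc2c1C1=C(Br)C(=O)NC1=O` differs from compound 3 by a rearrangement of the same atoms: 2-methylphenyl in place of 3-methylphenyl on an amide-type nitrogen. Going by the values given here, no measured step moves a methyl around the anilide ring; the nearest information is the step from compound 1 to compound 3, where adding a methyl to that ring left the partition coefficient unchanged, and the chain lengthening from compound 1 to compound 2, which was equally flat. Nothing in these three values suggests that shifting the methyl should move this assay beyond its scatter. The step implied by the estimate, no change at the digits printed from compound 3 to compound 4 (within the scatter), is therefore expected to be nil. Compound 4 is estimated at 2.56, within 2.26 to 2.86.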

Compound 4, partition coefficient: 2.56
Compound 4: middle estimate and measured number agree at the digits printed, within the range that was stated.
By their numbers in this assay, from the lowest: compounds 1, 2, 3 and 4 (each within the scatter of the next).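

Going by these compounds alone, with 2-methylphenyl in place of 3-methylphenyl on the amide-type nitrogen, this assay shows no change at the digits printed from compound 3 to compound 4 (within the scatter) and so gives a measured step for where the methyl sits on that ring, which the earlier compounds could not give. The methyl in this new place, set against hydrogen, also gives no change at the digits printed from compound 1 to compound 4 (within the scatter) and, set against the longer chain, gives no change at the digits printed from compound 2 to compound 4 (within the scatter) in the same assay, so all four compounds stand level at the digits printed. No supporting measurement bears on why these steps are flat.

The compounds shown leave open whether a methoxy group, a carboxylic acid or an amine on that ring would stay level with them in this assay as well. From the compounds shown here alone, a chain longer than that of compound 2 also remains open.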